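The compounds below may be only part of what the source reports. "The series", "measured", "known", "first", "only" and "open" are said of these compounds alone.

Compound 1 `O=S(=O)(/C=C/c1ccc(O)cc1)Cc1ccc(Nc2ncnc3ccccc23)cc1`: 100000 nM
Compound 2 `O=S(=O)(/C=C/c1ccc(Cl)cc1)Cc1ccc(Nc2ncnc3ccc(Br)cc23)cc1`: 15000 nM

Both compounds were tested in a functional assay on UACC-62 cells (Homo sapiens); a lower number here means a stronger inhibitor of growth, a higher number a weaker inhibitor of growth. Compound 2, at 15000 nM, has the lower number of the two, and the gap to compound 1 at 100000 nM lies beyond the scatter. These two compounds differ in more than one place, so their values do not show what any single change does.

Compound 3 `O=S(=O)(/C=C/c1ccc(O)cc1)Cc1ccc(Nc2ncnc3ccc(Br)cc23)cc1` departs from compound 2 in one place, with hydroxy in place of chloro on an aromatic carbon, para to a large group (hydroxy in place of chloro on an aromatic carbon). Within the data shown here, no measured pair shows this swap alone. Compound 3 carries the hydroxy group of compound 1 (100000 nM) and otherwise matches compound 2 (15000 nM), so a moderate move towards a higher number is expected, namely a 2.3-fold higher number from compound 2 to compound 3 (0.37 log units; beyond the scatter). For compound 3 the estimate is 35000 nM, with an expected range from 12000 nM to 100000 nM.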

Compound 3, concentration for 50% growth inhibition: 28000 nM
The estimate for compound 3 lay 1.3-fold (0.10 log units) above the measured number; measured number inside the range.
By their numbers in this assay, from the lowest: compounds 2 and 3 (each within the scatter of the next); then compound 1.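

In this assay, hydroxy in place of chloro on the aromatic carbon para to a large group gives a 1.9-fold higher number from compound 2 to compound 3 (0.27 log units; within the scatter), so at this position the two groups cannot be told apart, at least with bromo present on the core. Bromo in place of hydrogen on an aromatic carbon, with the hydroxy group kept, gives a 3.6-fold lower number from compound 1 to compound 3 (0.55 log units; beyond the scatter), the first single change in this set whose step lies beyond the scatter. Nothing given here offers a reason for either step.

Going by these compounds, whether chloro and hydroxy would also match without the bromo remains open, as does whether an amine or a carboxylic acid at the same position would give a different number. The compounds shown also leave open whether chloro or a methoxy group in place of the bromo would give a similar step.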